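Carboxy to Cyanoethyl on a Saturated Ring Carbon

The compounds below may be only part of what the source reports. "The series", "measured", "known", "first", "only" and "open" are said of these compounds alone.

Measured so far:
Compound 1, `Cc1nn([C@H](C)c2ccc(Cl)cc2Cl)c2nc(N3CC[C@H](N4CCC4)[C@H](C)C3)cnc12`: 218 nM
Compound 2, `Cc1nn([C@H](C)c2ccc(Cl)cc2Cl)c2nc(N3CC[C@H](N4CCC[C@H]4C(=O)O)[C@H](C)C3)cnc12`: "not determined" (no result reported)

In an assay on CCRF-CEM cells for antagonist activity at C-C chemokine receptor type 4 (Homo sapiens), read by CellTiter-Glo, with stated times of 30 min and 60 min, in the presence of a further agent that is not named here (a higher number here means a weaker inhibitor, a lower number a stronger inhibitor), compound 1 gives 218 nM. Compound 2 shares the core of compound 1 but carries a 2-carboxypyrrolidin-1-yl group in place of the azetidinyl group; for compound 2 this assay reports "not determined" (no result reported), so it stands nowhere on the numbers shown, and no step involving it can be sized. Compound 3, `Cc1nn([C@H](C)c2ccc(Cl)cc2Cl)c2nc(N3CC[C@H](N4CCC[C@H]4CCC#N)[C@H](C)C3)cnc12`, follows from compound 2 by 2-cyanoethyl in place of carboxy on a saturated ring carbon. For the measured compounds named here, no measured pair mirrors this change, so its direction and size are open. With compound 1 as the only anchor, compound 3 is expected to land near it, with a wide spread in either direction. The estimate for compound 3 in this assay is 150 nM, expected to fall between 40 nM and 600 nM.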

Compound 3, half-maximal inhibitory concentration: 865 nM
Compound 3: middle estimate off by 5.8-fold (0.76 log units), on the low side; the measured number lies above the stated range.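

For the compounds shown here, compound 3 gives the first number for a substituted five-membered ring at this position: in this assay, 2-(2-cyanoethyl)pyrrolidin-1-yl in place of azetidin-1-yl gives a 4.0-fold higher number from compound 1 to compound 3 (0.60 log units; beyond the scatter) and so a weaker inhibitor that still reads in the nanomolar range. The carboxy to 2-cyanoethyl change itself cannot be sized, as compound 2 has no number to set against compound 3. Nothing shown here accounts for the weaker reading.

The compounds shown do not separate the change of ring from the added 2-cyanoethyl chain. From the compounds shown here alone, how a plain pyrrolidin-1-yl, or an amine or a longer nitrile chain on the same saturated ring carbon, would read in this assay remains open.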